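Replacing a Nitrophenyl Group by a Dichlorophenyl Group

The source may hold more compounds than are shown below. What is called first, only, known or untested is meant among the compounds shown, and "the series" means these compounds.

Two compounds have so far been measured in a functional assay on Jurkat cells for inhibition of nuclear factor NF-kappa-B complex (Homo sapiens); a higher number here means a weaker inhibitor, a lower number a stronger inhibitor:

Compound 1, `CCOC(=O)c1cnc(-c2ccc(F)cc2)nc1NN1C(=O)C=C(C)C1=O`, gives 700 nM.
Compound 2, `CCOC(=O)c1cnc(-c2cccc([N+](=O)[O-])c2)nc1NN1C(=O)C=C(C)C1=O`, gives 7000 nM.

Compound 2 stands at the higher of these two numbers, that is, as the weaker inhibitor of the pair. For the measured compounds named here, its only neighbour is compound 1, and the one measured step is a 10-fold higher number from compound 1 to compound 2 (1.00 log units; beyond the scatter).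

The next compound, compound 3, `CCOC(=O)c1cnc(-c2cc(Cl)cc(Cl)c2)nc1NN1C(=O)C=C(C)C1=O`, differs from compound 2 in one place: 3,5-dichlorophenyl in place of 3-nitrophenyl on an aromatic carbon. Going by the values given here, no measured step covers this exact exchange. Among the compounds with values here, the only step available, a 10-fold higher number from compound 1 to compound 2 (1.00 log units; beyond the scatter), went from a phenyl bearing a single halogen to the nitrophenyl and weakened inhibition. Compound 3 carries a phenyl with two halogens in place of the nitrophenyl, so a move back toward the number of compound 1 is expected; still, 3,5-dichlorophenyl is not 4-fluorophenyl, and the return may well be only partial.

Compound 3 is therefore expected to give about 2000 nM in this assay, with a range from 500 nM to 8000 nM, which corresponds to an expected step of a 3.5-fold lower number from compound 2 to compound 3 (0.54 log units; beyond the scatter).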

Compound 3, half-maximal inhibitory concentration: 300 nM
Estimate against measurement, compound 3: 6.7-fold (0.82 log units) above, and the stated range ends above it.
By their numbers in this assay, from the lowest: compound 3; then compound 1; then compound 2.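

The exchange at this aromatic carbon gives a 23-fold lower number from compound 2 to compound 3 (1.37 log units; beyond the scatter) in this assay, which is the largest step seen so far and shows that the choice of group here can move the number widely. The 4-fluorophenyl of compound 1 also proves not to be the best of the groups shown, since the 3,5-dichlorophenyl gives a 2.3-fold lower number from compound 1 to compound 3 (0.37 log units; beyond the scatter) and so puts compound 3 ahead of both others, each by more than the scatter. All three compounds keep the same six-membered carbon ring at this place and differ only in what that ring carries, so changing those substituents alone is enough to shift the result in either direction.

For the compounds shown here, with only three compounds, it remains open whether the gain comes from having two chlorine atoms or from where they sit, and a plain phenyl, a 3-chlorophenyl, a 4-chlorophenyl or a 3,5-dimethoxyphenyl would help to separate these possibilities. Nothing available here gives a measured property or other evidence that explains why these groups differ.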